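The compounds below may be only part of what the source reports. "The series", "measured", "known", "first", "only" and "open" are said of these compounds alone.

Working notes on the series. Among the compounds with values here, compound 2 `O=C(NCc1ccc(S(=O)(=O)N2CCCCC2)cc1)c1cnc2nccn2c1` stands second highest of the three numbers so far in an assay for inhibition of Nicotinamide phosphoribosyltransferase (Homo sapiens), read by mass spectrometry, with stated times of 15 min and 30 min; on this read-out lower numbers stand for stronger inhibition and higher numbers for weaker inhibition: compound 2 gives 3 nM. Nearest is compound 3 `O=C(NCc1ccc(S(=O)(=O)c2cc(F)cc(F)c2)cc1)c1cnc2nccn2c1`, which in this assay gives 2 nM, and the step of a 1.5-fold lower number from compound 2 to compound 3 (0.18 log units; within the scatter) stays within the scatter. Furthest is compound 1 `O=C(NCc1ccc(S(=O)(=O)c2ccccc2)cc1)c1cc2ccncc2s1`, which in this assay gives 7 nM. Within the data shown here, compound 1 differs from compound 2 in two places at once, so no single step connects them, and the two values show only that compound 1 is the higher of the pair.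

As far as these compounds go, compound 4 `O=C(NCc1ccc(S(=O)(=O)N2CCCCC2)cc1)c1ccn2cncc2c1` is untested. It differs from compound 2 by a group of 9 heavy atoms (7 carbon, 2 nitrogen; one five-membered aromatic ring with 2 hetero atoms, one six-membered aromatic ring with 1 hetero atom) in place of a group of 9 heavy atoms (6 carbon, 3 nitrogen; one five-membered aromatic ring with 2 hetero atoms, one six-membered aromatic ring with 2 hetero atoms), on a carbonyl carbon. Among the measured compounds shown here, none of the measured steps touches the group on the carbonyl carbon: the one step on hand, from compound 2 to compound 3, concerns the sulfonyl sulfur and is within the scatter. For the measured compounds named here, the only other group on the carbonyl carbon is in compound 1, and its value cannot be read on its own because of the different sulfonyl group there. Going by the values given here, with no bearing step, no move beyond the scatter is expected in this assay, and the range is set wide because the change is untested. Compound 4 is therefore expected at 5 nM, between 1.5 nM and 16 nM. The expected step of a 1.7-fold higher number from compound 2 to compound 4 (0.22 log units; within the scatter) is estimated to fall within the scatter.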

Compound 4, half-maximal inhibitory concentration: 1700 nM
Beside the measured number, compound 4's estimate is 340-fold (2.53 log units) below it; measured number above the stated range.
By their numbers in this assay, from the lowest: compounds 3 and 2 (each within the scatter of the next); then compound 1; then compound 4.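

Within the data shown here, the swap on the carbonyl carbon gives a 570-fold higher number from compound 2 to compound 4 (2.75 log units; beyond the scatter) in this assay, whereas the only earlier step, a 1.5-fold lower number from compound 2 to compound 3 (0.18 log units; within the scatter), concerned the sulfonyl sulfur and stayed within the scatter. Among these compounds, this is the first reading of this place with the rest of the structure held fixed, and it shows that the number here can respond very strongly to the group on the carbonyl carbon. The two groups have the same count of 9 heavy atoms and the same ring sizes, differing in 7 carbon and 2 nitrogen against 6 carbon and 3 nitrogen and in 2 hydrogen-bond acceptors against 3, so a matching heavy-atom count does not keep the number in place, and nothing measured on hand accounts for the size of this step.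

Open, as far as these compounds go, is whether the group that enters in compound 4 would give a step of similar size with the 3,5-difluorophenyl on the sulfonyl sulfur, as in compound 3. Also open, from the compounds shown here alone, is how a simpler group on the same carbonyl carbon, such as a pyridin-3-yl or a plain phenyl, would read with the piperidin-1-yl kept.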